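Side-chain variation on the shared core: hydroxymethyl next

The source may hold more compounds than are shown below. What is called first, only, known or untested is meant among the compounds shown, and "the series" means these compounds.

Three compounds share one core and differ only in the group on a saturated chain carbon bound to an aromatic nitrogen. Compound 1 `O=c1c2ccccc2c(-c2cccnc2)nn1Cc1ccccc1` carries phenyl there; in an assay on isolated protein (Oryctolagus cuniculus) with Thromboxane-A synthase (Homo sapiens) as the target, tested at 1 uM (on this read-out higher numbers stand for more inhibition at the one concentration tested (going by the name of the read-out) and lower numbers for less inhibition), compound 1 gives 97%. Compound 2 `COCCn1nc(-c2cccnc2)c2ccccc2c1=O` carries methoxymethyl, and in this assay compound 2 gives 55%. Compound 3 `CCOC(=O)Cn1nc(-c2cccnc2)c2ccccc2c1=O` carries ethoxycarbonyl, and in this assay compound 3 gives 28%, the lowest of the three numbers. The steps are a number 42 percentage points lower from compound 1 to compound 2 (beyond the scatter), a number 69 percentage points lower from compound 1 to compound 3 (beyond the scatter) and a number 27 percentage points lower from compound 2 to compound 3 (beyond the scatter).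

Compound 4 `O=c1c2ccccc2c(-c2cccnc2)nn1CCO` is the next member: hydroxymethyl in place of ethoxycarbonyl on a saturated chain carbon bound to an aromatic nitrogen. The step that bears most directly on it is the one between methoxymethyl and ethoxycarbonyl, a number 27 percentage points lower from compound 2 to compound 3 (beyond the scatter), which is modest. Hydroxymethyl and methoxymethyl are both two-heavy-atom groups as counted above, so compound 4 is expected to sit closer to compound 2 than to compound 3, and the change is expected to read a number 22 percentage points higher from compound 3 to compound 4 (beyond the scatter). Among the compounds with values here, no measured step reaches phenyl-level numbers from a small chain group, so compound 4 is not expected to approach compound 1. The estimate for compound 4 in this assay is 50%, with a range from 25% to 75%.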

Compound 4, a percentage reported as inhibition, at one concentration (the size of the read-out at that concentration, not a potency): 69%
Compound 4: the middle estimate sits 19 percentage points below what was measured; the range from low to high includes it.
By their numbers in this assay, from the lowest: compound 3; then compound 2; then compound 4; then compound 1.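

In this assay, the smallest change in the series, hydrogen in place of methyl on an oxygen on a saturated carbon, still moves the number (a number 14 percentage points higher from compound 2 to compound 4 (beyond the scatter)), so this position responds to more than the swap of a whole group. The step from ethoxycarbonyl to hydroxymethyl is large (a number 41 percentage points higher from compound 3 to compound 4 (beyond the scatter)), and hydroxymethyl now ranks above the other two groups without a ring, which shows that a group without a ring can retain much of the inhibition seen with phenyl, although phenyl remains ahead (a number 28 percentage points lower from compound 1 to compound 4 (beyond the scatter)). No measurement at hand accounts for these steps.

Open questions remain on the same saturated chain carbon: whether an amine or a carboxylic acid there would read closer to hydroxymethyl or to ethoxycarbonyl, and whether a longer chain ending in hydroxyl would keep the number seen with the 2-hydroxyethyl chain. Also open, from the compounds shown here alone, is whether the lead of phenyl belongs to the aromatic ring as such, which cyclohexyl or pyridyl in its place would begin to test.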